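Methoxy to fluoro on the chalcone aryl ring

A few compounds are considered here, and "the series" means these few. Any claim that something is new, unique, unknown or untested is made for them only; others in the source may bear on it.

Compound 1 `Cc1cc(Nc2ccc(C(=O)/C=C/c3ccc4ccccc4c3)cc2)n2nc(SC(=O)c3csc4ccc(Cl)cc34)nc2n1` gives 35 nM in a functional assay on SW-620 cells (Homo sapiens) for cytotoxicity, read by MTT assay, with stated times of 4 h and 72 h, tested at 2 uM; on this read-out higher numbers stand for weaker inhibition and lower numbers for stronger inhibition. Compound 2 `COc1ccc(/C=C/C(=O)c2ccc(Nc3cc(C)nc4nc(SCc5nc6ccccc6[nH]5)nn34)cc2)cc1` gives 170 nM. Compound 3 `Cc1cc(Nc2ccc(C(=O)/C=C/c3ccc4ccccc4c3)cc2)n2nc(SCC(=O)c3ccccc3)nc2n1` gives 190 nM.

Among the three measured compounds, compound 2 stands second highest on these numbers. Its nearest neighbour is compound 3, whose number lies within the scatter of it, so no order between the two can be read. Compound 1 sits well apart, with a number beyond the scatter lower than that of compound 2.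

Compound 4 `Cc1cc(Nc2ccc(C(=O)/C=C/c3ccc(F)cc3)cc2)n2nc(SCc3nc4ccccc4[nH]3)nc2n1` has not yet been measured. It differs from compound 2 in one place: fluoro in place of methoxy on an aromatic carbon.

Among the compounds with values here, the only measured step that differs in a single place is a 5.4-fold higher number from compound 1 to compound 3 (0.73 log units; beyond the scatter), and that change sits on the sulfur, not on the aryl ring of the enone. Within the data shown here, no measured pair here speaks to swapping methoxy for fluoro on that ring; compounds 1 and 3 carry a naphthyl there instead, so their numbers do not isolate this change either. The expectation therefore rests on the change being small and on the neighbouring values clustering near compound 2, with no direction supported beyond the scatter.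

On that basis compound 4 is expected to give about 200 nM, within a range of 80 nM to 500 nM.

This estimate means the step of a 1.2-fold higher number from compound 2 to compound 4 (0.07 log units; within the scatter) is expected to lie within the usual scatter.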

Compound 4, half-maximal inhibitory concentration: 85 nM
Compound 4: middle estimate off by 2.4-fold (0.37 log units), on the high side, and the stated range covers the measured number.
By their numbers in this assay, from the lowest: compound 1; then compounds 4, 2 and 3 (each within the scatter of the next, the first and the last beyond it).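

Within the data shown here, with compound 4, the aryl ring of the enone is for the first time varied in a single place, whereas the only earlier single-place step, a 5.4-fold higher number from compound 1 to compound 3 (0.73 log units; beyond the scatter), lay on the sulfur and was read beyond the scatter. In this assay, the exchange of methoxy for fluoro on the aromatic carbon para to a large group gives a 2.0-fold lower number from compound 2 to compound 4 (0.30 log units; within the scatter), so this pair shows no readable difference even though the substituent goes from two heavy atoms and one hydrogen-bond acceptor to one heavy atom and no acceptor. No measurement offered here accounts for where either number falls, so the result stands as a description only.

The compounds shown leave open whether an amine, a carboxylic acid or a nitrile at this same place would also stay within the scatter of compound 2, since methoxy and fluoro are the only two substituents compared there. They also leave open whether the exchange of methoxy for fluoro would read the same with benzoylmethyl or (5-chloro-1-benzothiophen-3-yl)carbonyl on the sulfur.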